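The source may hold more compounds than are shown below. What is called first, only, known or untested is meant among the compounds shown, and "the series" means these compounds.

Series notes, values from a functional assay on SK-N-SH cells (Homo sapiens) for inhibition, read by MTT assay, with a stated time of 72 h, tested at 50 uM; on this read-out higher numbers stand for more inhibition of growth at the one concentration tested and lower numbers for less inhibition of growth.

- compound 1 `C=CCc1ccc(OCc2cn(-c3ccccc3Cl)nn2)c(O)c1` gives 42.8%
- compound 2 `C=CCc1ccc(OCc2cn(-c3cccc(C#N)c3)nn2)c(O)c1` gives 78.8%
- compound 3 `C=CCc1ccc(OCc2cn(-c3ccc(C(=O)c4ccccc4)cc3)nn2)c(O)c1` gives 58.1%

Compound 3 stands second of the three, above compound 1 and below compound 2, with both gaps beyond the scatter. The next compound to be measured is compound 4 `C=CCc1ccc(OCc2cn(-c3ccc(Br)cc3)nn2)c(O)c1`, which differs from compound 3 as follows: bromo in place of benzoyl on an aromatic carbon. In short, bromo replaces benzoyl on an aromatic carbon.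

Among the compounds with values here, the only measured step between two compounds differing in one place is a number 36 percentage points higher from compound 1 to compound 2 (beyond the scatter). It is large, but it involves neither benzoyl nor bromo. It shows that a single change on this aromatic ring can move the number well beyond the scatter, yet it gives no direction for the present change. No step beyond the scatter is therefore expected, and the range is kept wide. The expected step is a number 3.1 percentage points lower from compound 3 to compound 4 (within the scatter), with its direction uncertain. For compound 4 the estimated value is 55%, with an expected range from 35% to 75%.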

Compound 4, percent growth inhibition at one concentration: 61.7%
Estimate against measurement, compound 4: 6.7 percentage points below, and the stated range covers the measured number.
By their numbers in this assay, from the lowest: compound 1; then compounds 3 and 4 (each within the scatter of the next); then compound 2.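

In this assay, bromo in place of benzoyl gives a number 3.6 percentage points higher from compound 3 to compound 4 (within the scatter) and so removes 8 heavy atoms and a six-membered aromatic ring from this aromatic carbon, para to a large group, without a step beyond the scatter. The 4-bromophenyl group also falls between the other two groups on the aromatic nitrogen, with a number 17.1 percentage points lower from compound 2 to compound 4 (beyond the scatter) and a number 18.9 percentage points higher from compound 1 to compound 4 (beyond the scatter) as its steps, so 3-cyanophenyl stays above it and 2-chlorophenyl below it. No measurement bears on the cause of these steps.

Compounds 1 and 4 differ in both halogen and ring position, so the two effects cannot be separated. As far as these compounds go, it also remains open whether an amine or a carboxylic acid on this aromatic carbon would keep the number in the range of compounds 3 and 4.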